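Swapping a pyridine for a methoxyphenyl on the piperazine

A few compounds are considered here, and "the series" means these few. Any claim that something is new, unique, unknown or untested is made for them only; others in the source may bear on it.

Measured compounds:
Compound 1, `CCCc1nc(-c2ccccc2)c(CNCCCN2CCN(c3ccc(C(F)(F)F)cc3)CC2)o1`, gives 51.6% in an assay on HEK293 cells for inhibition of Voltage-dependent T-type calcium channel subunit alpha-1G (Homo sapiens), read by fluorescence, tested at 10 uM; a higher number here means more inhibition at the concentration tested (going by the name of the read-out), a lower number less inhibition.
Compound 2, `CCCc1nc(-c2ccccc2)c(CNCCN2CCN(c3ccccn3)CC2)o1`, gives 48.1% in this assay.

Compound 2 has the lower of the two numbers, though compound 1 sits only a little higher, within the scatter. Compound 3, `CCCc1nc(-c2ccccc2)c(CNCCN2CCN(c3ccccc3OC)CC2)o1`, differs from compound 2 in one place: 2-methoxyphenyl in place of pyridin-2-yl on an amine nitrogen in a ring. Within the data shown here, no measured pair shows what such a swap does here, so the expected step of a number 1.9 percentage points higher from compound 2 to compound 3 (within the scatter) is none beyond the scatter. Compound 3 is therefore estimated at 50%, with a range from 30% to 70%.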

Compound 3, a percentage reported as inhibition, at one concentration (the size of the read-out at that concentration, not a potency): 39.7%
For compound 3 the middle estimate is 10.3 percentage points above the measured one; the range from low to high includes it.
By their numbers in this assay, from the lowest: compounds 3, 2 and 1 (each within the scatter of the next, the first and the last beyond it).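

In this assay, 2-methoxyphenyl in place of pyridin-2-yl on an amine nitrogen in a ring gives a number 8.4 percentage points lower from compound 2 to compound 3 (within the scatter). This first one-place comparison therefore shows that, at this position, these two aromatic rings cannot be told apart by this read-out, even though one has a ring nitrogen and the other a carbon-only ring with a methoxy group. Nothing shown here offers an explanation for this step. Still open, from the compounds shown here alone, is whether a smaller group on the same nitrogen, such as methyl, or a carboxylic acid on the aromatic ring, would move the number beyond the scatter.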